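The source may report more compounds than this note shows. Statements on the series, on what has been measured and on what is new or still open speak of the compounds shown alone.

In an ADME assay on NIH3T3 cells (Mus musculus) for cytotoxicity (on this read-out higher numbers stand for lower toxicity in this test and lower numbers for higher toxicity in this test), compound 1 (`CC(C)(C)CC#Cc1cc2ncnc(Nc3ccc(OCc4cccc(F)c4)c(Cl)c3)c2s1`) gives > 50 uM as a limit of the assay. Compound 2 (`Fc1cccc(COc2ccc(Nc3ncnc4cc(C#CCN5CCNCC5)sc34)cc2Cl)c1`) gives > 50 uM and this too is a limit. Compound 3 (`COCC#Cc1cc2ncnc(Nc3ccc(OCc4cccc(F)c4)c(Cl)c3)c2s1`) gives > 50 uM and this is again a limit, so it has no exact place in the series, where the evidence is the limit of > 50 uM in this assay, at which 3 of the 3 values shown sit, so far. Going to compound 4 (`Fc1cccc(COc2ccc(Nc3ncnc4cc(C#CC5CCCC5)sc34)cc2Cl)c1`), cyclopentyl comes in place of methoxymethyl on a triple-bonded carbon (cyclopentyl in place of methoxymethyl on a triple-bonded carbon). Going by the values given here, three measured steps bear on this change, namely a step that the two limits leave unreadable from compound 1 to compound 3 and a step that the two limits leave unreadable from compound 2 to compound 3 and a step that the two limits leave unreadable from compound 1 to compound 2 and none has a readable size. No shift beyond the scatter is expected in this assay and the estimated step is a step that the limit leaves unreadable from compound 3 to compound 4 in either direction. Compound 4 is expected at 60 uM with an estimated range from 28 uM to 100 uM and may well report only a limit.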

Compound 4, half-maximal toxic concentration: > 100 uM
Compound 4 was reported as a limit; the forecaster's own chance of this, stated with the estimate: 85%; middle value at least 1.6-fold (0.22 log units) from the limit.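

Compound 4 gives > 100 uM in this assay, which is a limit, so its steps from compound 1, compound 2 and compound 3 cannot be read. As far as these compounds go, the exact toxic concentrations of all four compounds remain open, and with them whether the group on the triple-bonded carbon matters in this assay.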